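Adding a Third Methoxy Group to the Aryl Substituent

A few compounds are considered here, and "the series" means these few. Any claim that something is new, unique, unknown or untested is made for them only; others in the source may bear on it.

Compound 1 `Cc1cc(O)c(C2=NN(c3ccc(S(N)(=O)=O)cc3)C(/C=C/c3ccccc3)C2)cc1Cl`: 3940 nM
Compound 2 `COc1ccc(C2CC(c3cc(Cl)c(C)cc3O)=NN2c2ccc(S(N)(=O)=O)cc2)cc1OC`: 2580 nM

Both compounds were tested in a functional assay on MDA-MB-468 cells (Homo sapiens) for antiproliferative activity, with a stated time of 48 h; a higher number here means a weaker inhibitor of growth, a lower number a stronger inhibitor of growth. Going by the values given here, compound 2 stands on the lower of the two numbers, but its only neighbour is compound 1, and the step of a 1.5-fold lower number from compound 1 to compound 2 (0.18 log units; within the scatter) lies within the scatter, so the two cannot be separated on these data.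

Compound 3 `COc1ccc(C2CC(c3cc(Cl)c(C)cc3O)=NN2c2ccc(S(N)(=O)=O)cc2)c(OC)c1OC` keeps everything in compound 2 except one change: methoxy in place of hydrogen on an aromatic carbon. Among the compounds with values here, the single measured step, from compound 1 to compound 2, concerns a different part of the molecule, the group on the saturated ring carbon, and was itself within the scatter; no measured step adds or removes a methoxy group on this phenyl ring. There is therefore no basis to expect a shift in this assay beyond the scatter, in either direction. Compound 3 is expected to give about 2600 nM, in a range of 1000 nM to 6500 nM, which amounts to an expected step of a 1.0-fold higher number from compound 2 to compound 3 (0.00 log units; within the scatter).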

Compound 3, concentration for 50% growth inhibition: 2640 nM
Estimate against measurement, compound 3: 1.0-fold (0.01 log units) below; the measured number falls inside the stated range.
By their numbers in this assay, from the lowest: compounds 2, 3 and 1 (each within the scatter of the next).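

In this assay, methoxy in place of hydrogen on this aromatic carbon, ortho to a large group and ortho to a methoxy group, gives a 1.0-fold higher number from compound 2 to compound 3 (0.01 log units; within the scatter), so this added group brings no shift that can be told from the scatter. Going by these compounds alone, the trimethoxy compound also stays inseparable from the one with the open-chain group: 2,3,4-trimethoxyphenyl in place of 2-phenylethenyl on the saturated ring carbon gives a 1.5-fold lower number from compound 1 to compound 3 (0.17 log units; within the scatter), and the three compounds therefore cannot be ranked. Nothing available here explains this result.

On these data alone, whether an amine or a carboxylic acid on this aromatic carbon would give a step beyond the scatter remains open. So does whether a hydroxyl group or a longer chain such as butoxy there would do so.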